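The source may report more compounds than this note shows. Statements on the series, on what has been measured and on what is new or still open speak of the compounds shown alone.

Compound 1 `COc1ccc(-c2nn(-c3ccccc3)cc2C(=O)NOCc2ccccc2)cc1`: 2640 nM
Compound 2 `COc1ccc(-c2nn(-c3ccccc3)cc2C(=O)NOCc2ccccc2Cl)cc1`: 3480 nM
Compound 3 `COc1ccc(-c2nn(-c3ccccc3)cc2C(=O)NOCc2ccc(Cl)cc2Cl)cc1`: 5750 nM

All three were tested in a functional assay on HeLa cells (Homo sapiens) for antiproliferative activity, read by MTT assay, with a stated time of 48 h, in the presence of a further agent that is not named here; a lower number here means a stronger inhibitor of growth, a higher number a weaker inhibitor of growth. Compound 2 stands second highest of the three numbers, but its steps to the other two, a 1.3-fold higher number from compound 1 to compound 2 (0.12 log units; within the scatter) and a 1.7-fold higher number from compound 2 to compound 3 (0.22 log units; within the scatter), both fall within the scatter, so no order among them is secure. Only a 2.2-fold higher number from compound 1 to compound 3 (0.34 log units; beyond the scatter) reaches beyond it.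

Compound 4 `O=C(NOCc1ccccc1Cl)c1cn(-c2ccccc2)nc1-c1ccc(F)cc1` differs from compound 2 in one place: fluoro in place of methoxy on an aromatic carbon. Every measured step alters the ring on the saturated chain carbon bound to an oxygen; none touches the ring that carries the methoxy group, so there is no measured guide for this change. The step is therefore expected to stay within the scatter, a 1.0-fold higher number from compound 2 to compound 4 (0.00 log units; within the scatter). Compound 4 is estimated at 3500 nM, with a range from 1500 nM to 8500 nM.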

Compound 4, concentration for 50% growth inhibition: 36400 nM
Estimate against measurement, compound 4: 10-fold (1.02 log units) below; measured number outside the range, above it.
By their numbers in this assay, from the lowest: compounds 1, 2 and 3 (each within the scatter of the next, the first and the last beyond it); then compound 4.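

Going by these compounds alone, changing the ring that carries the methoxy group, which the earlier compounds left untouched, moves the result in this assay far more than any earlier step, giving a 10-fold higher number from compound 2 to compound 4 (1.02 log units; beyond the scatter) with fluoro in place of methoxy. This place on the ring, para to a large group, is therefore sensitive to the group it carries. Nothing measured here bears on the reason for this rise.

As far as these compounds go, whether the rise comes from losing methoxy or from gaining fluoro stays open. Hydrogen, hydroxyl, ethoxy or dimethylamino at this place would help to separate the two.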